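A few compounds are considered here, and "the series" means these few. Any claim that something is new, unique, unknown or untested is made for them only; others in the source may bear on it.

Measured compounds:
compound 1 `O=[N+]([O-])c1ccc(Cl)c(/C=C/c2nc3ncccc3[nH]2)c1`: 1800 nM
compound 2 `O=[N+]([O-])c1ccc(Cl)c(/C=C/c2nc3ncc(Br)cc3[nH]2)c1`: 59900 nM
compound 3 `N#Cc1ccc(/C=C/c2nc3ncccc3[nH]2)cc1`: 86600 nM

All three numbers come from a functional assay on SK-BR-3 cells (Homo sapiens) for antiproliferative activity, read by MTT assay, with a stated time of 72 h; on this read-out lower numbers stand for stronger inhibition and higher numbers for weaker inhibition. The change from compound 1 to compound 2 is bromo in place of hydrogen on an aromatic carbon, and it gave a 33-fold higher number from compound 1 to compound 2 (1.52 log units; beyond the scatter). Compound 3 is built on a different core; the difference between the core of compound 1 and that of compound 3 is not broken down here. The values of compound 3 and compound 2 lie within the usual scatter of each other, whereas compound 1 sits well apart from both.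

Compound 4 `N#Cc1ccc(/C=C/c2nc3ncc(Br)cc3[nH]2)cc1` is not yet measured. For the measured compounds named here, it differs from compound 3 by bromo in place of hydrogen on an aromatic carbon, which is the same change as the one from compound 1 to compound 2, at the same place. Going by the values given here, for compound 4 a step of a 3.5-fold higher number from compound 3 to compound 4 (0.54 log units; beyond the scatter) is expected in this assay; this rests on the only precedent, namely a 33-fold higher number from compound 1 to compound 2 (1.52 log units; beyond the scatter), weakened somewhat since compound 3 already starts from 86600 nM. Compound 4 is therefore expected to give 300000 nM, plausibly between 90000 nM and 1500000 nM, with a fair chance that only a limit is reported.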

Compound 4, half-maximal inhibitory concentration: 4310 nM
Estimate against measurement, compound 4: 70-fold (1.84 log units) above; measured number below the stated range.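

In this assay, bromo in place of hydrogen on an aromatic carbon gave a 20-fold lower number from compound 3 to compound 4 (1.30 log units; beyond the scatter), which runs opposite to the earlier step with the same change at the same place: the same change on two cores in this assay, a 33-fold higher number (1.52 log units; beyond the scatter) from compound 1 to compound 2 and a 20-fold lower number (1.30 log units; beyond the scatter) from compound 3 to compound 4, 670-fold (2.83 log units) apart, beyond the scatter of two such steps

The step therefore does not carry over from the core of compound 1 to the core of compound 3 in either direction or size, and a step read on one of these cores gives no safe estimate for the other. Two pairs do not show why the steps part, which feature of the cores sets the direction, or how a third core would respond.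

From the compounds shown here alone, it remains open whether the reversal is particular to bromo or would also appear with a methyl, methoxy or amine group at the same place. Going by these compounds, it also remains open whether a core carrying only the nitro group or only the chloro would follow compound 2 or compound 4 under this change.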